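A few compounds are considered here, and "the series" means these few. Any claim that something is new, unique, unknown or untested is made for them only; others in the source may bear on it.

Measured so far:
compound 1, `CCCCC(Oc1ccc2c(=O)c(-c3ccc(O)cc3)coc2c1)C(=O)OCC`: >> 9000 nM in an assay (Cricetulus griseus) for inhibition of Monoamine oxidase (Homo sapiens); on this read-out lower numbers stand for stronger inhibition and higher numbers for weaker inhibition
compound 2, `O=c1c(-c2ccc(O)cc2)coc2cc(OCCCCCCO)ccc12`: > 9000 nM

Both read-outs are limits of the assay, not numbers. Compound 1 is reported only as the limit >> 9000 nM (the limit of >> 9000 nM in this assay, at which 1 of the 2 values shown sits). Compound 2 is reported only as the limit > 9000 nM (the limit of > 9000 nM in this assay, at which 1 of the 2 values shown sits). Compound 1 therefore stands at the weak end of what this assay can show, and the two limits give no order between compound 1 and compound 2.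

Compound 3, `CCCCCCC(Oc1ccc2c(=O)c(-c3ccc(O)cc3)coc2c1)C(=O)OCC`, is not yet measured. It differs from compound 1 by ethyl in place of hydrogen on a saturated chain carbon, five bonds along the chain from a carbonyl carbon and an oxygen on an aromatic ring. Within the data shown here, no measured pair shows the effect of such a change. Because compound 1 gives only >> 9000 nM, compound 3 is expected to remain beyond the reach of this assay as well. The expected step is a step that the limit leaves unreadable from compound 1 to compound 3, no more than the scatter. For compound 3 the estimate is 20000 nM, with a range from 9000 nM to 60000 nM, most likely again reported as a limit.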

Compound 3, half-maximal inhibitory concentration: >> 9000 nM
Compound 3 gave a limit, no number (the forecaster's own chance of this, stated with the estimate: 90%); the middle value is on the limit's open side.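

Among these compounds, compound 1 and compound 3 are both reported only as limits in this assay, and no step between them can be read. The compounds shown leave open how strongly either one inhibits, and whether ethyl in place of hydrogen on that saturated chain carbon changes inhibition at all.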